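Alkyl size at the ether oxygen in a rat inhibition assay

A few compounds are considered here, and "the series" means these few. Any claim that something is new, unique, unknown or untested is made for them only; others in the source may bear on it.

Measured so far:
compound 1 `COc1ccccc1-c1ncc(C(=O)O)c(=O)[nH]1` — 10 mg/kg
compound 2 `CC(C)Oc1ccccc1-c1ncc(C(=O)O)c(=O)[nH]1` — 0.8 mg/kg

Both compounds share one core and differ only in the alkyl group carried by an oxygen on an aromatic ring. In a functional assay on the whole organism (strain Sprague-Dawley) for inhibition, with Rattus norvegicus as the target, with a stated time of 10 min (a lower number here means that less compound is needed, a higher number that more compound is needed for the effect), compound 1 gives 10 mg/kg, while compound 2 gives 0.8 mg/kg. For the measured compounds named here, the single step recorded so far is a 13-fold lower number from compound 1 to compound 2 (1.10 log units; beyond the scatter), so compound 2 stands at the lowest number of the two, with compound 1 as its only neighbour.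

Compound 3 `CCCCOc1ccccc1-c1ncc(C(=O)O)c(=O)[nH]1` has not yet been measured. It continues the same idea: butyl in place of isopropyl on an oxygen on an aromatic ring. Going by the values given here, a butyl chain is longer than isopropyl, and the one step available, from methyl to isopropyl, brought a large improvement in this assay. Whether a further lengthening helps again, stays level or reverses cannot be told from one step, so only a cautious extrapolation is possible.

On that basis compound 3 is expected to need about 0.5 mg/kg, with a plausible span from 0.15 mg/kg to 2 mg/kg. The expected step is a 1.6-fold lower number from compound 2 to compound 3 (0.20 log units; within the scatter), a modest gain that might still lie within the scatter.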

Compound 3, dose for 50% inhibition: 0.5 mg/kg
The estimate for compound 3 equals the measured number at the digits printed; the measured number falls inside the stated range.
By their numbers in this assay, from the lowest: compounds 3 and 2 (each within the scatter of the next); then compound 1.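

The larger step from methyl holds for more than one alkyl group on this oxygen: in this assay, butyl gives a 20-fold lower number from compound 1 to compound 3 (1.30 log units; beyond the scatter), so the large change seen with isopropyl is not unique to that group. Exchanging isopropyl for butyl gives a 1.6-fold lower number from compound 2 to compound 3 (0.20 log units; within the scatter), so this assay cannot separate the two groups, even though butyl has one more carbon and a different shape, and the large drop seen on leaving methyl is not repeated at this step. Nothing measured here explains why compound 2 and compound 3 need so much less than compound 1.

On these data alone, the series jumps from methyl to groups of three and four carbons, so ethyl and propyl remain open, and with them the question of where along this short run the large step arises. As far as these compounds go, it is also open whether a longer chain such as hexyl, a ring-bearing group such as benzyl, or a butyl chain ending in an amine would keep the number in this assay as low as that of compound 3 .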